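The source may report more compounds than this note shows. Statements on the series, on what has been measured and on what is new or still open speak of the compounds shown alone.

Measured in a functional assay on MDA-MB-231 cells (Homo sapiens) for antiproliferative activity, read by CellTiter-Glo, with a stated time of 96 h; on this read-out higher numbers stand for weaker inhibition and lower numbers for stronger inhibition:
- Compound 1 `COc1ccc(-c2nsc3c2NC(=O)CC3c2cccc(Cl)c2)cc1`: 1620 nM
- Compound 2 `COc1ccc(-c2nsc3c2NC(=O)CC3c2ccc(F)cc2)cc1`: > 2000 nM (a limit)

Compound 2 has no exact number in this series. Among the compounds with values here, its entry of > 2000 nM is a limit of the assay, and it is the only reading of that kind: the limit of > 2000 nM in this assay, at which 1 of the 2 values shown sits.

Compound 3 `COc1ccc(-c2nsc3c2NC(=O)CC3c2ccsc2)cc1` keeps the shared core and carries thiophen-3-yl in place of 4-fluorophenyl on a saturated ring carbon.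

Within the data shown here, only one measured step bears on this change, as it also swaps the aromatic ring on that same carbon: an at least 1.2-fold higher number from compound 1 to compound 2 (0.09 log units; that floor lies within the scatter). That step gives no sign of a change beyond the scatter, although it rests on a limit and shows only a floor. The data therefore set no direction for the new swap, and no large step is expected in this assay. Compound 3 is expected to stay in the same weak range as compound 1, which gives 1620 nM. Compound 3 may well be found to reach the limit of the assay.

The estimated value for compound 3 is 1800 nM, with an expected range of 700 nM to 4000 nM. This estimate means an expected at least 1.1-fold lower number from compound 2 to compound 3 (0.04 log units; that floor lies within the scatter).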

Compound 3, half-maximal inhibitory concentration: 192 nM
Beside the measured number, compound 3's estimate is 9.4-fold (0.97 log units) above it, outside the stated range (below it).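

In this assay, the saturated ring carbon proves sensitive to the aromatic ring it carries, which the earlier pair could not show: thiophen-3-yl gives an at least 10-fold lower number from compound 2 to compound 3 (1.01 log units; beyond the scatter) and an 8.4-fold lower number from compound 1 to compound 3 (0.93 log units; beyond the scatter). Both steps lie beyond the scatter, and in both a six-membered aromatic ring of carbon only gives way to a five-membered aromatic ring with one hetero atom, so the stronger inhibition holds against either halogen-bearing phenyl group shown. Compound 2 gives > 2000 nM, which is a limit, so the larger step shows only a floor and its true size remains unknown: the limit of > 2000 nM in this assay, at which 1 of the 3 values shown sits.

The compounds shown cannot separate the contributions of the sulfur atom, the five-membered ring and the loss of the halogen, as all three change together in each step. As far as these compounds go, it remains open how an unsubstituted phenyl, a thiophen-2-yl or a furan-3-yl group on the same carbon would read in this assay, and these would help show which of those changes matters.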